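A few compounds are considered here, and "the series" means these few. Any claim that something is new, unique, unknown or untested is made for them only; others in the source may bear on it.

Measured in a functional assay on MCF7 cells (Homo sapiens) for inhibition, read by XTT assay, with a stated time of 72 h; on this read-out lower numbers stand for stronger inhibition of growth and higher numbers for weaker inhibition of growth:
Compound 1 `C=Cc1ccnc(C#Cc2ccc3ncn(-c4ccnc(N)n4)c3c2)c1`: 1260 nM
Compound 2 `C#Cc1ccnc(C#Cc2ccc3ncn(-c4ccnc(N)n4)c3c2)c1`: > 10000 nM

Compound 2 sits at the end of the measurable range: its > 10000 nM is a limit of the assay and not a number. This is the limit of > 10000 nM in this assay, at which 1 of the 2 values shown sits. Among the compounds with values here, the only measured step, an at least 7.9-fold higher number from compound 1 to compound 2 (0.89 log units; beyond the scatter), is ethynyl in place of vinyl on an aromatic carbon, and it lies beyond the scatter.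

Compound 3 `C=Cc1ccnc(C#Cc2ccc3ncn(-c4ccnc(N)n4)c3c2)n1` differs from compound 2 as follows: a group of 8 heavy atoms (6 carbon, 2 nitrogen; one six-membered aromatic ring with 2 hetero atoms) in place of a group of 8 heavy atoms (7 carbon, 1 nitrogen; one six-membered aromatic ring with 1 hetero atom), on a triple-bonded carbon. The entering group has a double bond outside aromatic rings where the leaving group has a triple bond, and its six-membered aromatic ring differs in its hetero atoms. Read in reverse, the step of an at least 7.9-fold higher number from compound 1 to compound 2 (0.89 log units; beyond the scatter) leads to the expectation of a lower number in this assay, beyond the scatter. Within the data shown here, no measured step covers the change of aromatic ring, so this expectation remains loose. The estimated change is an at least 3.3-fold lower number from compound 2 to compound 3 (0.52 log units; beyond the scatter). For compound 3 the expected value is 3000 nM, with an estimated range of 800 nM to 10000 nM.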

Compound 3, concentration for 50% growth inhibition: 631 nM
Compound 3: the middle estimate sits 4.8-fold (0.68 log units) above what was measured; the measured number lies below the stated range.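

In this assay, replacing 4-ethynylpyridin-2-yl on the triple-bonded carbon with the group that has a double bond outside aromatic rings and an aromatic ring with 2 hetero atoms gives a value that can be read as a number, with an at least 15-fold lower number from compound 2 to compound 3 (1.19 log units; beyond the scatter). From the compounds shown here alone, compound 2 stands at a limit of the assay and not at a number, so the full size of this step stays unknown: the limit of > 10000 nM in this assay, at which 1 of the 3 values shown sits. The comparison of the two vinyl compounds gives a 2.0-fold lower number from compound 1 to compound 3 (0.30 log units; within the scatter), so among the compounds shown, the change of aromatic ring alone makes no difference that can be read, and the large step from compound 2 goes with the double bond taking the place of the triple bond rather than with the ring.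

The compounds shown leave open how an ethynyl group would behave on the aromatic ring with 2 hetero atoms, which would separate the two changes directly. They also leave open whether an ethyl group, an amine or a longer chain in place of the vinyl group would keep this level of growth inhibition.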